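A Bromophenyl Analogue of a Triazole-Linked Bicyclic Lactam

The source may hold more compounds than are shown below. What is called first, only, known or untested is meant among the compounds shown, and "the series" means these compounds.

Compound 1 `CC1(C)[C@H]2CC[C@]1(C)N(Cc1cn(-c3ccccc3C#N)nn1)C(=O)C2` gives 260 nM in a functional assay on SGC-7901 cells (Homo sapiens) for inhibition, read by MTT assay, with a stated time of 24 h; on this read-out higher numbers stand for weaker inhibition and lower numbers for stronger inhibition. Compound 2 `COc1ccccc1-n1cc(CN2C(=O)C[C@@H]3CC[C@@]2(C)C3(C)C)nn1` gives 280 nM, and compound 3 `CC1(C)[C@H]2CC[C@]1(C)N(Cc1cn(-c3cccc(O)c3)nn1)C(=O)C2` gives 270 nM. Compound 1 is separated from compound 2 by a 1.1-fold higher number from compound 1 to compound 2 (0.03 log units; within the scatter) and from compound 3 by a 1.0-fold higher number from compound 1 to compound 3 (0.02 log units; within the scatter), so its number sits alongside the other two rather than apart from them. Compound 4 `CC1(C)[C@H]2CC[C@]1(C)N(Cc1cn(-c3cccc(Br)c3)nn1)C(=O)C2` carries the change (3-bromophenyl in place of 2-cyanophenyl on an aromatic nitrogen). The step from compound 2 to compound 3, a 1.0-fold lower number from compound 2 to compound 3 (0.02 log units; within the scatter), also exchanges the group on the aromatic nitrogen and likewise stays within the scatter. No aryl exchange on this nitrogen has so far moved the number beyond the scatter, so compound 4 is expected to show a step of a 1.0-fold higher number from compound 1 to compound 4 (0.02 log units; within the scatter), and its value is estimated at 270 nM, within 140 nM to 520 nM.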

Compound 4, half-maximal inhibitory concentration: 120 nM
Beside the measured number, compound 4's estimate is 2.3-fold (0.35 log units) above it; measured number outside the range, below it.
By their numbers in this assay, from the lowest: compound 4; then compounds 1, 3 and 2 (each within the scatter of the next).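

Going by these compounds alone, on the aromatic nitrogen, the aryl group can move the number in this assay after all: 3-bromophenyl is the first exchange here to pass the scatter, with a 2.2-fold lower number from compound 1 to compound 4 (0.34 log units; beyond the scatter) and a 2.3-fold lower number from compound 2 to compound 4 (0.37 log units; beyond the scatter) as its steps. Bromo in place of hydroxy on the aromatic carbon gives a 2.3-fold lower number from compound 3 to compound 4 (0.35 log units; beyond the scatter) on its own, so the shift goes with the bromo group, since compound 3, with 3-hydroxyphenyl, stays within the scatter of compound 1. Nothing available accounts for this shift.

The compounds shown leave open whether bromo is special or whether chloro or iodo on that carbon would give the same step. They also leave open how an amine or a carboxylic acid there would compare.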